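This account rests on a few compounds, and the source may have more. Where it says the series, first, only, none or still open, it means among the compounds named here.

In a functional assay on BXPC-3 cells (Homo sapiens) for cytotoxicity, read by MTT assay, with a stated time of 72 h (a higher number here means a weaker inhibitor, a lower number a stronger inhibitor), compound 1 `Nc1ccc(-c2ccc(NC3=CC(=O)c4ncncc4C3=O)cc2)cc1` gives 3500 nM, the lowest of the two numbers at hand. Compound 2 `O=C1C=CC(=O)c2ncncc21`, the shared core alone, gives 19400 nM in this assay, a gap beyond the usual scatter. Compound 3 `O=C1C(Nc2ccc(Oc3ccccc3)cc2)=CC(=O)c2ncncc21` has not yet been measured in this assay; it differs from compound 1 by phenoxy in place of 4-aminophenyl on an aromatic carbon. Within the data shown here, no measured pair here tracks this change, so the step is expected to be small, estimated as a 1.4-fold higher number from compound 1 to compound 3 (0.15 log units; within the scatter), toward a slightly weaker inhibitor and perhaps within the scatter. Compound 3 is therefore estimated at 5000 nM, with a range of 1500 nM to 16000 nM.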

Compound 3, half-maximal inhibitory concentration: 3600 nM
For compound 3 the middle estimate is 1.4-fold (0.14 log units) above the measured one; measured number inside the range.
By their numbers in this assay, from the lowest: compounds 1 and 3 (each within the scatter of the next); then compound 2.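

Phenoxy in place of 4-aminophenyl on an aromatic carbon gives a 1.0-fold higher number from compound 1 to compound 3 (0.01 log units; within the scatter) in this assay and so shows no readable difference at this position. The hydrogen-bond donor counted on 4-aminophenyl is absent from phenoxy, yet the numbers for compound 1 and compound 3 lie within the scatter of each other. Nothing at hand gives a reason for this result. From the compounds shown here alone, whether a carboxylic acid or a longer chain on this aromatic carbon would give a similar number stays open. So does whether this equivalence would hold for other groups at this place.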